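The source may hold more compounds than are shown below. What is called first, only, known or untested is meant among the compounds shown, and "the series" means these compounds.

Series notes. In an ADME assay on cells (Hepatocyte, Homo sapiens) for metabolic stability, read by LC-MS, with a stated time of 60 min, tested at 1 uM (a higher number here means faster removal of the compound, a lower number slower removal), compound 1 `COc1cc(N(CC(C)C)c2cccc(C(F)(F)F)c2)cnc1C(=O)[C@H]1C[C@@H]1C(=O)O` gives 2.9 uL/min. Compound 2 `COc1cc(N(CC2CC2)c2cc(Cl)c(F)cc2F)cnc1C(=O)[C@H]1C[C@@H]1C(=O)O` reaches only a limit of this assay, reported as < 1.5 uL/min, so no number stands for it; this is the limit of < 1.5 uL/min in this assay, at which 1 of the 2 values shown sits. Compound 3 `COc1cc(N(CC(C)C)c2cc(Cl)c(F)cc2F)cnc1C(=O)[C@H]1C[C@@H]1C(=O)O` is not yet measured. The change from compound 2 to compound 3 is isopropyl in place of cyclopropyl on a saturated chain carbon bound to a nitrogen on an aromatic ring. Among the measured compounds shown here, no measured pair covers this change; a modest rise, likely still within the usual scatter, is expected, so compound 3 is expected to take the step of an at least 1.3-fold higher number from compound 2 to compound 3 (0.12 log units; that floor lies within the scatter). Compound 3 is estimated at 2 uL/min, with a range from 1 uL/min to 4 uL/min.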

Compound 3, intrinsic clearance in a liver preparation (reported as CLH), per the amount of preparation that the assay uses in the Hepatocyte assay: 4.9 uL/min
Beside the measured number, compound 3's estimate is 2.5-fold (0.39 log units) below it; the measured number lies above the stated range.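

Among the compounds shown here, in the Hepatocyte assay, isopropyl in place of cyclopropyl on this saturated chain carbon gives the first change beyond the scatter, an at least 3.2-fold higher number from compound 2 to compound 3 (0.51 log units; beyond the scatter), whereas the aryl change gives a 1.7-fold higher number from compound 1 to compound 3 (0.23 log units; within the scatter). Compound 2 stands at a limit and not at a number, so the size of that first step is only a floor: the limit of < 1.5 uL/min in the Hepatocyte assay, at which 1 of the 3 values shown sits. In a physicochemical assay for lipophilicity, read by LC-MS, in phosphate buffer, measured as octanol-water partition, at pH 7.4 (a higher number here means a more lipophilic compound, a lower number a more polar compound), compound 2 gives 1.1 and compound 3 gives 1.3, two values within the scatter of each other.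

Going by these compounds, the true size of the step stays open, as does how a longer chain or a cyclobutyl group on the same saturated chain carbon would read in the Hepatocyte assay.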